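The compounds below may be only part of what the source reports. "The series", "measured", "known", "first", "only" and "open" are said of these compounds alone.

Compound 3, with the structure `COc1ccc2nc(C)cc(OCC(=O)Nc3cc(C)c(F)c(C)c3)c2c1`, has been measured in a physicochemical assay for solubility, in phosphate buffer, measured as kinetic solubility, with a stated time of 1 h, at pH 7.4 (a lower number here means a less soluble compound, a higher number a more soluble compound), where compound 3 gives 31500 nM, the highest of the two numbers shown. Within the data shown here, its nearest neighbour is compound 2, `COc1ccc2nc(C)cc(OCC(=O)Nc3cc(C)c(OC)c(C)c3)c2c1`, which in this assay gives 17000 nM; the step of a 1.9-fold higher number from compound 2 to compound 3 (0.27 log units; within the scatter) is the only one between compounds that differ in one place, and it lies within the scatter. Compound 1, `Cc1cc(C)cc(NC(=O)COc2cc(C)nc3ccc(OCc4ccccc4)cc23)c1`, sits at a limit of the assay rather than a number, < 1000 nM, as recorded in the limit of < 1000 nM in this assay, at which 1 of the 3 values shown sits.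

The compound not yet measured is compound 4, `COc1ccc2nc(C)cc(OCC(=O)Nc3nc(C)c(C)s3)c2c1`. It differs from compound 3 in this way: 4,5-dimethyl-1,3-thiazol-2-yl in place of 4-fluoro-3,5-dimethylphenyl on an amide-type nitrogen. Among the measured compounds shown here, no measured step in this set exchanges one aromatic ring for another, so the single measured step, between compound 2 and compound 3, bears on this change only loosely, and being within the scatter it gives no direction. The estimate for compound 4 in this assay is therefore expected near compound 3, at 25000 nM, within a range from 7000 nM to 80000 nM. The expected step of a 1.3-fold lower number from compound 3 to compound 4 (0.10 log units; within the scatter) is not expected to go clearly beyond the scatter.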

Compound 4, solubility: 31500 nM
Beside the measured number, compound 4's estimate is 1.3-fold (0.10 log units) below it; measured number inside the range.
By their numbers in this assay, from the lowest: compounds 2, 3 and 4 (each within the scatter of the next). At a limit, below all of these: compound 1.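

Until now, the only one-place step among these compounds was a fluoro for methoxy exchange on the aromatic ring, with that ring itself kept in place. Among these compounds, the step of no change at the digits printed from compound 3 to compound 4 (within the scatter) in this assay is the first to replace the whole aromatic group on the amide-type nitrogen, and it shows that a five-membered aromatic ring with 2 hetero atoms can stand there in place of the six-membered carbon ring without a step beyond the scatter. Nothing given here explains this result.

On these data alone, whether an amine or a carboxylic acid carried on the 4,5-dimethyl-1,3-thiazol-2-yl group, or a saturated cyclohexyl group on the amide-type nitrogen, would give a step beyond the scatter remains open. Compound 1 gives < 1000 nM, a limit of the assay, and as it differs from compound 3 in more than one place, it does not bear on this change.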